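Removing a chloro group on a shared core

The source may report more compounds than this note shows. Statements on the series, on what has been measured and on what is new or still open speak of the compounds shown alone.

Three compounds on one core were tested in an assay on ileum (strain Hartley) with 5-hydroxytryptamine receptor 3A (Cavia porcellus) as the target; on this read-out higher numbers stand for larger maximal responses and lower numbers for smaller maximal responses. Compound 1 `CN1CCN(c2nc3cccc(Cl)c3o2)CC1` gives 0.24. Compound 2 `CN1CCN(c2nc3cc(Cl)cc(Cl)c3o2)CC1` gives 0.14. Compound 3 `CCc1cc(Cl)cc2nc(N3CCN(C)CC3)oc12` gives 0.17. Compound 2 and compound 3 differ in one place, (ethyl in place of chloro on an aromatic carbon), and the step is a number 0.030 higher from compound 2 to compound 3 (within the scatter). Compound 2 and compound 1 also differ in one place, (hydrogen in place of chloro on an aromatic carbon), and the step is a number 0.10 higher from compound 2 to compound 1 (within the scatter). Compound 4 `CCc1cccc2nc(N3CCN(C)CC3)oc12` is not yet measured; it differs from compound 3 by hydrogen in place of chloro on an aromatic carbon. Within the data shown here, this is the same kind of change as the one from compound 2 to compound 1, though there the place was meta to a chloro group and here it is meta to an ethyl group. Compound 4 is expected to show a step of a number 0.080 higher from compound 3 to compound 4 (within the scatter) in this assay because the step a number 0.10 higher from compound 2 to compound 1 (within the scatter) was of the same kind and small. Compound 4 is therefore estimated at 0.25, between 0.12 and 0.38.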

Compound 4, intrinsic activity: the largest response reached, as a fraction of the reference agonist's: 0.15
For compound 4 the middle estimate is 0.10 above the measured one, within the range that was stated.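

In this assay, hydrogen in place of chloro gives a number 0.020 lower from compound 3 to compound 4 (within the scatter), and ethyl in place of chloro gives a number 0.090 lower from compound 1 to compound 4 (within the scatter). The hydrogen-for-chloro change does not separate the two cores: the same change on two cores in this assay, a number 0.10 higher (within the scatter) from compound 2 to compound 1 and a number 0.020 lower (within the scatter) from compound 3 to compound 4, 0.12 apart, within the scatter of two such steps. The ethyl-for-chloro change reads the same way, but with every step inside the scatter this shows only that no dependence on the core can be seen, not that either change has a real effect that carries from one core to another: the same change on two cores in this assay, a number 0.030 higher (within the scatter) from compound 2 to compound 3 and a number 0.090 lower (within the scatter) from compound 1 to compound 4, 0.12 apart, within the scatter of two such steps.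

The compounds shown leave open what an amine, a carboxylic acid or a longer chain would do in place of chloro. They also leave open whether any such group would give a step beyond the scatter on both cores.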